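The source may hold more compounds than are shown below. What is called first, only, known or untested is meant among the compounds shown, and "the series" means these compounds.

In a functional assay on MCF7 cells (Homo sapiens) for antiproliferative activity, read by CellTiter-Glo, with a stated time of 5 days (a higher number here means a weaker inhibitor, a lower number a stronger inhibitor), compound 1 `N#Cc1ccc(/C(=C(\c2ccc(/C=C/C(=O)O)cc2)c2ccc3scnc3c2)C2CCC2)c(Cl)c1` gives 1.4 nM, while compound 2 `N#Cc1cc(Cl)ccc1/C(=C(\c1ccc(/C=C/C(=O)O)cc1)c1ccc2scnc2c1)C1CCC1` gives 0.9 nM. The two differ only by 4-chloro-2-cyanophenyl in place of 2-chloro-4-cyanophenyl on a double-bonded chain carbon bound to a double-bonded chain carbon and a saturated ring carbon, and that change made a step of a 1.6-fold lower number from compound 1 to compound 2 (0.19 log units; within the scatter). Compound 3 `N#Cc1ccc(/C(=C(\c2ccc(/C=C/C(=O)O)cc2)c2ccc(-c3cncs3)cc2)C2CCC2)c(Cl)c1` carries a different core, (4-(1,3-thiazol-5-yl)phenyl in place of 1,3-benzothiazol-5-yl on a double-bonded chain carbon bound to an aromatic carbon and a double-bonded chain carbon); in this assay compound 3 gives 2.9 nM, which is a step of a 2.1-fold higher number from compound 1 to compound 3 (0.32 log units; beyond the scatter) and leaves compound 3 with the highest number of the three. Compound 4 `N#Cc1cc(Cl)ccc1/C(=C(\c1ccc(/C=C/C(=O)O)cc1)c1ccc(-c2cncs2)cc1)C1CCC1` repeats on the core of compound 3 the same change already seen, (4-chloro-2-cyanophenyl in place of 2-chloro-4-cyanophenyl on a double-bonded chain carbon bound to a double-bonded chain carbon and a saturated ring carbon), at the same place. Going by the values given here, the only guide to its size is the earlier step of a 1.6-fold lower number from compound 1 to compound 2 (0.19 log units; within the scatter), which lay within the scatter. Compound 4 is therefore expected to show a comparably small step, a 1.6-fold lower number from compound 3 to compound 4 (0.21 log units; within the scatter), in this assay. Compound 4 is estimated at 1.8 nM, with a likely range from 0.8 nM to 4.5 nM.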

Compound 4, half-maximal inhibitory concentration: 4.3 nM
For compound 4 the middle estimate is 2.4-fold (0.38 log units) below the measured one; low and high end bracket the measured number.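

In this assay, placing 4-chloro-2-cyanophenyl in place of 2-chloro-4-cyanophenyl on the core of compound 3 gave a 1.5-fold higher number from compound 3 to compound 4 (0.17 log units; within the scatter), which does not differ from the same change on the core of compound 1: the same change on two cores in this assay, a 1.6-fold lower number (0.19 log units; within the scatter) from compound 1 to compound 2 and a 1.5-fold higher number (0.17 log units; within the scatter) from compound 3 to compound 4, 2.3-fold (0.36 log units) apart, within the scatter of two such steps. The move from 1,3-benzothiazol-5-yl to 4-(1,3-thiazol-5-yl)phenyl gave a 4.8-fold higher number from compound 2 to compound 4 (0.68 log units; beyond the scatter), which also agrees with its earlier step: the same change on two cores in this assay, a 2.1-fold higher number (0.32 log units; beyond the scatter) from compound 1 to compound 3 and a 4.8-fold higher number (0.68 log units; beyond the scatter) from compound 2 to compound 4, 2.3-fold (0.36 log units) apart, within the scatter of two such steps. Going by these compounds alone, both changes therefore carried between these cores within the scatter, but this rests on only two pairs for each change, and it does not show that they would carry to any other core, nor does it fix a direction for the first change, whose steps both lie within the scatter.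

The compounds shown leave open how a primary amide in place of the carboxylic acid would behave in this assay. They also leave open the effect of fluorine in place of the chlorine.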